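Chain Lengthening in an Indole Series Against Breast Cancer Cells

The source may hold more compounds than are shown below. What is called first, only, known or untested is meant among the compounds shown, and "the series" means these compounds.

Compound 1, `CCCCc1ccc2[nH]c(-c3ccc(C)cc3)c(C=O)c2c1`: 34 nM
Compound 2, `CCCCc1ccc2[nH]c(-c3ccc(CC)cc3)c(C=O)c2c1`: 27 nM
Compound 3, `CCCCc1ccc2[nH]c(-c3ccc(OC)cc3)c(/C=N\C)c2c1`: 6 nM

All three were tested in a functional assay on MDA-MB-231 cells (Homo sapiens) for antiproliferative activity, with a stated time of 4 days; on this read-out higher numbers stand for weaker inhibition and lower numbers for stronger inhibition. Compound 2 differs from compound 1 by methyl in place of hydrogen on a saturated chain carbon bound to an aromatic carbon, and that change produced a 1.3-fold lower number from compound 1 to compound 2 (0.10 log units; within the scatter). Compound 3 rests on a different core; the difference between the two cores is not broken down here, but its value stands beyond the scatter from both compound 1 and compound 2.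

Compound 4, `CCCCCc1ccc2[nH]c(-c3ccc(OC)cc3)c(/C=N\C)c2c1`, has not yet been measured. It differs from compound 3 by methyl in place of hydrogen on a saturated chain carbon, four bonds along the chain from an aromatic carbon. This is the same kind of change as from compound 1 to compound 2, though the place differs: there the carbon was bound to an aromatic carbon, here it lies four bonds along the chain from an aromatic carbon. Because the earlier step was a 1.3-fold lower number from compound 1 to compound 2 (0.10 log units; within the scatter), a step of similar size is expected here, a 1.2-fold lower number from compound 3 to compound 4 (0.08 log units; within the scatter). Compound 4 is therefore expected to give 5 nM, with a likely range from 2 nM to 12 nM.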

Compound 4, half-maximal inhibitory concentration: 6 nM
For compound 4 the middle estimate is 1.2-fold (0.08 log units) below the measured one; low and high end bracket the measured number.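

In this assay the added methyl gave no change at the digits printed from compound 3 to compound 4 (within the scatter). Set beside the earlier step, the same change behaves alike on the two cores: the same change on two cores in this assay, a 1.3-fold lower number (0.10 log units; within the scatter) from compound 1 to compound 2 and no change at the digits printed (within the scatter) from compound 3 to compound 4, 1.3-fold (0.10 log units) apart, within the scatter of two such steps. Among the compounds shown here, this shows only that neither step moved the number beyond the scatter in this one assay; with just two pairs, and the methyl added on a carbon bound to an aromatic carbon in one and four bonds along the chain from an aromatic carbon in the other, it does not show that the change would carry to further cores or places. The compounds shown leave open whether a longer chain would still leave the number unmoved. They also leave open what an amine or a carboxylic acid in place of this chain would do in this assay.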